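Swapping one aromatic group on a weak inhibitor

This account rests on a few compounds, and the source may have more. Where it says the series, first, only, none or still open, it means among the compounds named here.

- Compound 1 `COc1cc(O)cc(O)c1C(=O)/C=C/c1ccc(C)cc1`: > 50000 nM (a limit of the assay)
- Compound 2 `COc1cc(/C=C/C(=O)c2c(O)cc(O)cc2OC)cc(OC)c1`: 13300 nM
- Compound 3 `COc1cc(OC)c(C(=O)/C=C/c2ccc(O)cc2)c(OC)c1`: 40600 nM

These three compounds were tested in a functional assay on HeLa cells (Homo sapiens) for inhibition, read by MTT assay, with a stated time of 72 h; on this read-out higher numbers stand for weaker inhibition and lower numbers for stronger inhibition. Compound 1 gives only a limit (> 50000 nM) and not a number. That leaves two true numbers to compare. Compound 3 (40600 nM) has the higher number and compound 2 (13300 nM) the lower, and the gap between them lies beyond the usual scatter. Compound 3 is therefore the weaker inhibitor of this pair.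

The next compound to be measured is compound 4 `COc1cc(OC)c(C(=O)/C=C/c2ccccc2OC)c(OC)c1`. It differs from compound 3 in one place: on a double-bonded chain carbon bound to a double-bonded chain carbon, 2-methoxyphenyl stands in place of 4-hydroxyphenyl (2-methoxyphenyl in place of 4-hydroxyphenyl on a double-bonded chain carbon bound to a double-bonded chain carbon). Within the data shown here, no measured pair here isolates this change, so the starting point is simply compound 3 at 40600 nM as its nearest relative. The expected result is a 1.6-fold lower number from compound 3 to compound 4 (0.21 log units; within the scatter) and this estimated step stays within the scatter, so no real change in either direction is expected. The estimate for compound 4 is 25000 nM with an expected range from 9000 nM to 50000 nM in this test.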

Compound 4, half-maximal inhibitory concentration: 19600 nM
Compound 4: middle estimate off by 1.3-fold (0.11 log units), on the high side; low and high end bracket the measured number.
By their numbers in this assay, from the lowest: compounds 2 and 4 (each within the scatter of the next); then compound 3. At a limit, above all of these: compound 1.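

In this assay, among these compounds, this is the first step that can be read at this position on the double-bonded chain carbon: with 2-methoxyphenyl in place of 4-hydroxyphenyl, the result is a 2.1-fold lower number from compound 3 to compound 4 (0.32 log units; beyond the scatter). On this shared core, the hydrogen-bond donor of the 4-hydroxyphenyl group is therefore not required for the inhibition seen, since the 2-methoxyphenyl group has none and inhibition is modestly stronger rather than lost. The change alters both the group on the aromatic ring and where it sits, and nothing measured here accounts for the step.

Going by these compounds, it remains open which part of the swap carries the step, and 2-hydroxyphenyl or 4-methoxyphenyl at the same place would help separate the two. Also open, on these data alone, is how an amine or a carboxylic acid on this aromatic ring would compare with compound 4 at 19600 nM, and whether any group at this place can bring much stronger inhibition on this core.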